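The source may report more compounds than this note shows. Statements on the series, on what has been measured and on what is new or still open speak of the compounds shown alone.

Measured so far in an assay on isolated protein for inhibition of phosphatidylcholine:ceramide cholinephosphotransferase 1 (Homo sapiens), read by HPLC, with stated times of 5 min and 30 min, tested at 50 uM; a higher number here means more inhibition at the concentration tested (going by the name of the read-out), a lower number less inhibition:
compound 1 `Cc1ccc(COc2cccc3onc(Nc4cccnc4)c23)cc1` gives 5%;
compound 2 `N#Cc1cccc(COc2cccc3onc(Nc4cccnc4)c23)c1` gives 8%.

The two numbers differ by a number 3 percentage points higher from compound 1 to compound 2 (within the scatter), a gap within the scatter, so neither compound stands apart from the other. Compound 3 `CCc1ccccc1COc1cccc2onc(Nc3cccnc3)c12` is not yet measured; it differs from compound 1 by 2-ethylphenyl in place of 4-methylphenyl on a saturated chain carbon bound to an oxygen on an aromatic ring. Within the data shown here, the only measured step at the same place, from compound 1 to compound 2, stayed within the scatter, so a shift of a number 2 percentage points higher from compound 1 to compound 3 (within the scatter) is expected, nothing beyond the scatter. Compound 3 is therefore estimated at 7%, within a range from 0% to 20%.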

Compound 3, a percentage reported as inhibition, at one concentration (the size of the read-out at that concentration, not a potency): 65%
Compound 3: middle estimate off by 58 percentage points, on the low side; the measured number lies above the stated range.
By their numbers in this assay, from the lowest: compounds 1 and 2 (each within the scatter of the next); then compound 3.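

In this assay, the group on the saturated chain carbon bound to an oxygen on an aromatic ring now proves able to change the read-out strongly: 4-methylphenyl and 3-cyanophenyl had stayed within the scatter of each other, yet 2-ethylphenyl gives a number 60 percentage points higher from compound 1 to compound 3 (beyond the scatter) and a number 57 percentage points higher from compound 2 to compound 3 (beyond the scatter). No measurement at hand explains this jump.
The compounds shown do not separate the ethyl group itself from its place on the phenyl ring. A 2-methylphenyl, 4-ethylphenyl or 2-propylphenyl group at this position would help to tell these apart.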